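Pyridin-2-yl for 4-fluoro-3-methylphenyl: cytotoxicity in the series

A few compounds are considered here, and "the series" means these few. Any claim that something is new, unique, unknown or untested is made for them only; others in the source may bear on it.

Compound 1 `CS(=O)(=O)Nc1ccc2c(c1)S(=O)(=O)C=C(c1c(O)c3cc(F)ccc3n(Cc3ccc(F)cc3)c1=O)N2`: in an ADME assay on 2209-23 cells (Homo sapiens) for cytotoxicity, read by WST assay (a lower number here means that less compound is tolerated, a higher number that more compound is tolerated), compound 1 gives only the assay limit > 50000 nM.
Compound 2 `Cc1cc(Cn2c(=O)c(C3=CS(=O)(=O)c4cc(NS(C)(=O)=O)ccc4N3)c(O)c3cc(F)ccc32)ccc1F`: in this assay compound 2 likewise gives only the assay limit > 50000 nM.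

Within the data shown here, compound 2 thus stands at a limit in this assay, and the one further value shown is a limit as well. The step that the two limits leave unreadable from compound 1 to compound 2 is unreadable, since both ends sit at the limit; the evidence is the limit of > 50000 nM in this assay, at which 2 of the 2 values shown sit.

Compound 3 `CS(=O)(=O)Nc1ccc2c(c1)S(=O)(=O)C=C(c1c(O)c3cc(F)ccc3n(Cc3ccccn3)c1=O)N2` differs from compound 2 by pyridin-2-yl in place of 4-fluoro-3-methylphenyl on a saturated chain carbon bound to an aromatic nitrogen. The only measured step bears on it weakly: it is not readable, and no shown value leaves the limit. No step beyond the scatter is therefore expected for compound 3 in this assay; the estimate for compound 3 is 50000 nM, range 25000 nM to 100000 nM, most likely again reported as a limit. The expected step is a number no higher from compound 2 to compound 3 (the limit leaves the size open).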

Compound 3, half-maximal cytotoxic concentration: > 50000 nM
Compound 3 gave a limit, no number (the forecaster's own chance of this, stated with the estimate: 85%); the middle value sits exactly at the limit.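

No new step can be read among compound 1, compound 2 and compound 3 in this assay, where each gives a limit and not a number: the limit of > 50000 nM in this assay, at which 3 of the 3 values shown sit.

The compounds shown leave open whether 4-fluoro-3-methylbenzyl and (pyridin-2-yl)methyl differ at all in cytotoxicity.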